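The compounds below may be only part of what the source reports. "The series", "measured", "known", "first", "only" and "open" are said of these compounds alone.

Measured compounds:
- Compound 1 `Cc1ccc2oc(SCC(=O)Nc3ccc(-c4nc(-c5ccccc5)c(-c5ccccc5)n4C)cc3)nc2c1` gives 69.8% in a functional assay on HT-29 cells (Homo sapiens) for cytotoxicity, read by MTT assay, with a stated time of 24 h, tested at 80 ug/mL; on this read-out higher numbers stand for a stronger effect at the one concentration tested and lower numbers for a weaker effect.
- Compound 2 `CN1CCN(CC(=O)Nc2ccc(-c3nc(-c4ccccc4)c(-c4ccccc4)n3C)cc2)CC1` gives 53.1% in this assay.

Compound 2 stands lowest of the two numbers; its nearest neighbour is compound 1, separated by a number 16.7 percentage points lower from compound 1 to compound 2 (beyond the scatter), a change at the saturated chain carbon bound to the carbonyl carbon, where 4-methylpiperazin-1-yl replaces (5-methyl-1,3-benzoxazol-2-yl)sulfanyl.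

Compound 3 `CN(C)/C=C/N1CCN(CC(=O)Nc2ccc(-c3nc(-c4ccccc4)c(-c4ccccc4)n3C)cc2)CC1` differs from compound 2 at another place: 2-(dimethylamino)ethenyl in place of methyl on an amine nitrogen in a ring. Within the data shown here, the only measured step, a number 16.7 percentage points lower from compound 1 to compound 2 (beyond the scatter), alters the group on the chain carbon, not the amine nitrogen in the ring, so it does not bear on this change. Nothing measured speaks to exchanging methyl for 2-(dimethylamino)ethenyl on that ring nitrogen. The expectation for this assay is therefore no step beyond the scatter, a number 1.1 percentage points lower from compound 2 to compound 3 (within the scatter), with wide uncertainty. Compound 3 is estimated at 52%, within a range of 32% to 70%.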

Compound 3, a percentage reported as activity, at one concentration (the size of the read-out at that concentration, not a potency): 45.4%
For compound 3 the middle estimate is 6.6 percentage points above the measured one, and the stated range covers the measured number.
By their numbers in this assay, from the lowest: compounds 3 and 2 (each within the scatter of the next); then compound 1.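

In this assay, exchanging methyl for 2-(dimethylamino)ethenyl on the amine nitrogen in the ring gives a number 7.7 percentage points lower from compound 2 to compound 3 (within the scatter), so this added bulk of atoms on that nitrogen leaves the read-out within the scatter. The larger group does not close the gap to the sulfanyl compound: a number 24.4 percentage points lower from compound 1 to compound 3 (beyond the scatter), so on the saturated chain carbon both piperazine groups stand beyond the scatter from (5-methyl-1,3-benzoxazol-2-yl)sulfanyl. No measurement shown here accounts for either step.

The compounds shown leave open whether a different group on that ring nitrogen, such as a longer alkyl chain or an acetyl group, would move the read-out beyond the scatter. They also leave open how potency changes, since each compound is described at a single concentration.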